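Methoxy for Methyl on a Five-Ring Fused Core

The compounds below may be only part of what the source reports. "The series", "measured", "known", "first", "only" and "open" are said of these compounds alone.

Measured so far:
Compound 1, `COc1ccc2[nH]c(-c3ccc[nH]3)c(C3CC(=O)NC3=O)c2c1`, 6000 nM
Compound 2, `Cc1ccc2[nH]c3c4cn[nH]c4c4c(c3c2c1)C(=O)NC4=O`, > 100000 nM

Of the compounds shown here, two have been tested in a functional assay on PC-3 cells (Homo sapiens) for cytotoxicity, read by MTT assay, with a stated time of 72 h; a lower number here means a stronger inhibitor, a higher number a weaker inhibitor. Compound 1 `COc1ccc2[nH]c(-c3ccc[nH]3)c(C3CC(=O)NC3=O)c2c1` gives a clear number, 6000 nM. Compound 2 `Cc1ccc2[nH]c3c4cn[nH]c4c4c(c3c2c1)C(=O)NC4=O` is built on a different core of five fused rings, and in this assay compound 2 gives > 100000 nM, which is a limit of the assay and not a number. This is where compound 2 stands: at the weak end of what has been recorded, at the limit of > 100000 nM in this assay, at which 1 of the 2 values shown sits. Within the data shown here, no step between compound 1 and compound 2 has been worked out, so the two values show only that one compound yields a number and the other does not.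

Compound 3 `COc1ccc2[nH]c3c4cn[nH]c4c4c(c3c2c1)C(=O)NC4=O` keeps the core of compound 2 and differs from it in one place: methoxy in place of methyl on an aromatic carbon. Among the measured compounds shown here, no measured pair shows a change of this kind on this core, so there is no measured step to lean on. A single small exchange of this sort is expected to move the result little, and the step of a number no higher from compound 2 to compound 3 (the limit leaves the size open) is expected to stay within the usual scatter. Compound 3 is therefore estimated at 100000 nM, with a range from 20000 nM to 300000 nM, and a real chance that the assay again returns only a limit.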

Compound 3, half-maximal inhibitory concentration: > 100000 nM
Compound 3: a limit, no number; the forecaster's own chance of this, stated with the estimate: 60%; the middle value lies on the limit itself.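

Among these compounds, compound 2 and compound 3 each return only a limit of the assay and not a number, so no step between them can be read. Both stand at the same place: the limit of > 100000 nM in this assay, at which 2 of the 3 values shown sit. From the compounds shown here alone, whether methoxy in place of methyl on this core changes the result at all stays open, as does the true strength of either compound.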